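Chloro and pyridinyl variations on one amide-bearing core

A few compounds are considered here, and "the series" means these few. Any claim that something is new, unique, unknown or untested is made for them only; others in the source may bear on it.

Measured compounds:
Compound 1 `C#CCn1cc(C(=O)NC(CC(=O)Nc2ccccc2)c2ccccc2)c(=O)c2cccnc21`: 7200 nM
Compound 2 `C#CCn1cc(C(=O)NC(CC(=O)Nc2ccccc2)c2ccccc2)c(=O)c2ccc(Cl)nc21`: > 10000 nM

In a functional assay on DU-145 cells (Homo sapiens) for cytotoxicity, read by MTT assay, with a stated time of 72 h (on this read-out higher numbers stand for weaker inhibition and lower numbers for stronger inhibition), compound 1 gives 7200 nM. Compound 2 reaches only a limit of this assay, > 10000 nM, the point described by the limit of > 10000 nM in this assay, at which 1 of the 2 values shown sits. Among the compounds with values here, the one measured step, an at least 1.3-fold higher number from compound 1 to compound 2 (0.14 log units; that floor lies within the scatter), therefore gives a floor rather than a number, and that floor lies within the scatter.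

Compound 3 `C#CCn1cc(C(=O)NC(CC(=O)Nc2ccccn2)c2ccccc2)c(=O)c2ccc(Cl)nc21` differs from compound 2 by pyridin-2-yl in place of phenyl on an amide-type nitrogen. Within the data shown here, no measured step touches this change; the single step on record concerns chloro in place of hydrogen on an aromatic carbon, so nothing here tells how pyridin-2-yl in place of phenyl on an amide-type nitrogen shifts this assay. Starting from a limit, compound 3 is expected to stay weak, with the expected step that the limit leaves unreadable from compound 2 to compound 3 not beyond the scatter. Compound 3 is estimated at 15000 nM, between 5000 nM and 50000 nM.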

Compound 3, half-maximal inhibitory concentration: 4900 nM
The estimate for compound 3 lay 3.1-fold (0.49 log units) above the measured number; measured number outside the range, below it.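

In this assay, putting pyridin-2-yl in place of phenyl on the amide-type nitrogen gives an at least 2.0-fold lower number from compound 2 to compound 3 (0.30 log units; that floor lies within the scatter). Compound 3 gives a number, 4900 nM, so a chloro-bearing member of this set now has a readable value, and the change at this position is seen to leave a measurable response rather than a limit. The true size of the step cannot be read, and even its floor does not clear the scatter, because compound 2 stands at a limit: the limit of > 10000 nM in this assay, at which 1 of the 3 values shown sits.

From the compounds shown here alone, what the same change does on the core of compound 1, without the chloro, stays open. Also open, going by these compounds, is how other groups on this amide-type nitrogen would read, such as pyridin-3-yl, cyclohexyl or a longer alkyl chain, and how an amine in place of the chloro would read.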